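The source may report more compounds than this note shows. Statements on the series, on what has been measured and on what is new or still open speak of the compounds shown alone.

Measured so far in a functional assay on HepG2 cells (Homo sapiens) for inhibition, read by MTT assay, with a stated time of 3 days; a lower number here means a stronger inhibitor, a higher number a weaker inhibitor:
- compound 1 `CC[C@H](C)[C@@H](NCC(=O)NNC(=O)COc1ccc(-c2nc3ccccc3s2)cc1OC)C(=O)O`: 3990 nM
- compound 2 `COc1cc(-c2nc3ccccc3s2)ccc1OCC(=O)NNC(=O)CN[C@@H](CS)C(=O)O`: 3120 nM
- compound 3 `COc1cc(-c2nc3ccccc3s2)ccc1OCC(=O)NNC(=O)CN[C@@H](CCSC)C(=O)O`: 3780 nM

Compound 3, at 3780 nM, lies within the scatter of both other values, so the three compounds cannot be ranked. The next compound to be read is compound 4 `COc1cc(-c2nc3ccccc3s2)ccc1OCC(=O)NNC(=O)CN1CCC[C@H]1C(=O)O`, which is not yet measured. The change is 2-carboxypyrrolidin-1-yl in place of (1-carboxy-3-(methylsulfanyl)propyl)amino on a saturated chain carbon bound to a carbonyl carbon: 2-carboxypyrrolidin-1-yl in place of (1-carboxy-3-(methylsulfanyl)propyl)amino, on a saturated chain carbon bound to a carbonyl carbon.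

The nearest evidence is the three measured swaps of the group on the amine nitrogen: a 1.3-fold lower number from compound 1 to compound 2 (0.11 log units; within the scatter), a 1.1-fold lower number from compound 1 to compound 3 (0.02 log units; within the scatter) and a 1.2-fold higher number from compound 2 to compound 3 (0.08 log units; within the scatter). All three stay within the scatter. Within the data shown here, none of them places that nitrogen in a five-membered non-aromatic ring, so this change has no measured precedent and the range is kept wide. The expected result is a 1.1-fold lower number from compound 3 to compound 4 (0.02 log units; within the scatter), with no shift beyond the scatter in either direction. For compound 4 the estimated value is 3600 nM, with an expected range of 1700 nM to 7500 nM.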

Compound 4, half-maximal inhibitory concentration: 2650 nM
Compound 4: the middle estimate sits 1.4-fold (0.13 log units) above what was measured; the measured number falls inside the stated range.
By their numbers in this assay, from the lowest: compounds 4, 2, 3 and 1 (each within the scatter of the next).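

In this assay, the saturated chain carbon bound to a carbonyl carbon now carries a group with a five-membered non-aromatic ring, 2-carboxypyrrolidin-1-yl, and the steps to it are a 1.4-fold lower number from compound 3 to compound 4 (0.15 log units; within the scatter), a 1.2-fold lower number from compound 2 to compound 4 (0.07 log units; within the scatter) and a 1.5-fold lower number from compound 1 to compound 4 (0.18 log units; within the scatter). This place therefore accepts the ring in addition to the three open-chain amino groups, and the four compounds cannot be ranked, even though the entering group has one hydrogen-bond donor where the group in compound 3 has two. No measurement shown here accounts for these readings.

From the compounds shown here alone, all four compounds keep the carboxylic acid, so it remains open whether a methyl ester in its place, or a plain amine without it, would move the number beyond the scatter. Going by these compounds, a longer chain between the amine nitrogen and the carboxylic acid is equally open.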